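Will compound 4 hold the level of compound 2?

This account rests on a few compounds, and the source may have more. Where it says the series, first, only, none or still open, it means among the compounds named here.

In an ADME assay on microsomes from liver (Rattus norvegicus) for metabolic stability, read by LC-MS, with a stated time of 10 min, tested at 0.5 uM (a higher number here means that more of the compound is left, a lower number that less of the compound is left), compound 2 (`c1ccc2c(c1)CN[C@@H](CN(CCCN1CCNCC1)[C@H]1CCCc3cccnc31)C2`) stands highest of the three numbers (100%), above compound 1 (`c1ccc2c(c1)CN[C@H](CN(CCCN1CCNCC1)[C@H]1CCCc3cccnc31)C2`) at (88%) and compound 3 (`c1ccc2c(c1)CN[C@@H](CN(CC[C@@H]1CCCNC1)[C@H]1CCCc3cccnc31)C2`) at (28%). Compound 4 (`c1cnc2c(c1)CN[C@H](CN(CCCN1CCNCC1)[C@H]1CCCc3cccnc31)C2`) differs from compound 2 in one place (a group of 10 heavy atoms (8 carbon, 2 nitrogen; one six-membered non-aromatic ring with 1 hetero atom, one six-membered aromatic ring with 1 hetero atom) in place of a group of 10 heavy atoms (9 carbon, 1 nitrogen; one six-membered non-aromatic ring with 1 hetero atom, one six-membered aromatic ring of carbon only), on a saturated chain carbon bound to an amine nitrogen). Within the data shown here, no measured step makes this exchange. The modest step (a number 12 percentage points higher from compound 1 to compound 2 (beyond the scatter)) concerns the same group, but it involves configuration alone (the fact that compounds 1 and 2 differ only in the configuration as drawn). The large step (a number 72 percentage points lower from compound 2 to compound 3 (beyond the scatter)) lies in the (piperazin-1-yl)methyl part, which compound 4 keeps. No step beyond the scatter is therefore expected, and the estimated change is small (a number 8 percentage points lower from compound 2 to compound 4 (within the scatter)). For compound 4 the expected value is (92%), with an estimated range from (72%) to (100%).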

Compound 4, percent of the compound remaining: 87%
Compound 4: the middle estimate sits 5 percentage points above what was measured, and the stated range covers the measured number.
By their numbers in this assay, from the lowest: compound 3; then compounds 4 and 1 (each within the scatter of the next); then compound 2.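

In this assay, the group whose aromatic ring holds 1 hetero atom, in place of 1,2,3,4-tetrahydroisoquinolin-3-yl, gives two readings: a number 13 percentage points lower from compound 2 to compound 4 (beyond the scatter), yet a number 1 percentage points lower from compound 1 to compound 4 (within the scatter). The exchange on a saturated chain carbon bound to an amine nitrogen therefore reads differently according to which of two reference compounds is taken, and those two references are set apart by configuration alone: the fact that compounds 1 and 2 differ only in the configuration as drawn

The compounds shown leave open whether a fluorine on that aromatic ring would keep the number. They also leave open how the same exchange reads alongside the piperidin-3-yl group of compound 3.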